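Methyl for fluoro on the aniline ring of compound 1

This account rests on a few compounds, and the source may have more. Where it says the series, first, only, none or still open, it means among the compounds named here.

Compound 1, `Fc1cccc(-c2nc(Nc3ccccc3F)c3cc(F)ccc3n2)c1`: > 50000 nM
Compound 2, `Oc1ccccc1Nc1nc(-c2cccc(F)c2)nc2ccc(F)cc12`: > 50000 nM
Compound 3, `Nc1cccc(Nc2nc(-c3cccc(F)c3)nc3ccc(F)cc23)c1`: > 50000 nM

In a functional assay on MCF7 cells (Homo sapiens) for cytotoxicity, read by MTT assay, with a stated time of 48 h (a lower number here means a stronger inhibitor, a higher number a weaker inhibitor), compound 1 gives > 50000 nM, which is a limit of the assay and not a number. Compound 2 likewise gives only a limit, > 50000 nM. Compound 3 also stands at a limit, > 50000 nM. Compound 1 therefore has no measured place on a scale, only the limit it shares with the other two.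

Compound 4, `Cc1ccccc1Nc1nc(-c2cccc(F)c2)nc2ccc(F)cc12`, differs from compound 1 as follows: methyl in place of fluoro on an aromatic carbon. Going by the values given here, no measured step changes this position in this way. The steps that exist, a step that the two limits leave unreadable from compound 1 to compound 2 and a step that the two limits leave unreadable from compound 1 to compound 3, cannot be read in size, and a step that the two limits leave unreadable from compound 2 to compound 3 is just as unreadable, because of the limit of > 50000 nM in this assay, at which 3 of the 3 values shown sit. Among the compounds with values here, there is thus no measured step to lean on, only the shared limit.

Compound 4 is expected to give 50000 nM, most likely again as a limit, with a range from 20000 nM to 100000 nM. The step this estimate implies, a number no higher from compound 1 to compound 4 (the limit leaves the size open), is expected to be none beyond the scatter.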

Compound 4, half-maximal inhibitory concentration: > 50000 nM
Compound 4 ended at the assay's limit (the forecaster's own chance of this, stated with the estimate: 80%); the middle value sits exactly at the limit.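

Compound 4 stands at the same limit as compound 1, compound 2 and compound 3, so none of the steps from those three to compound 4 can be read in size: the limit of > 50000 nM in this assay, at which 4 of the 4 values shown sit.

The compounds shown leave open whether swapping the group on this ring changes the activity at all, since none of the four has a measured number.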